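The compounds below may be only part of what the source reports. "The series", "measured", "known", "first", "only" and "open" are said of these compounds alone.

Compound 1 `CCOc1ccc(-c2ncnn2-c2cc(OC)c(OC)c(OC)c2)cc1Cl`: 3 nM
Compound 2 `COc1cc(-n2ncnc2-c2ccc(Cl)c(Cl)c2)cc(OC)c1OC`: > 10000 nM

Both have been tested in a functional assay on Jurkat cells (Homo sapiens) for antiproliferative activity, read by MTT assay, with a stated time of 72 h; on this read-out higher numbers stand for weaker inhibition and lower numbers for stronger inhibition. Compound 1 gives 3 nM in this assay. For compound 2 only a limit of the test is reported in this assay, namely > 10000 nM; this is a limit, not a number (the limit of > 10000 nM in this assay, at which 1 of the 2 values shown sits). For the measured compounds named here, the single change that separates the two, chloro in place of ethoxy on an aromatic carbon, is reflected in an at least 3300-fold higher number from compound 1 to compound 2 (3.52 log units; beyond the scatter).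

Compound 3 `COc1cc(-n2ncnc2-c2ccc(F)cc2)cc(OC)c1OC` has not yet been measured. It differs from compound 2 by 4-fluorophenyl in place of 3,4-dichlorophenyl on an aromatic carbon. Going by the values given here, the one measured step, from compound 1 to compound 2, touches the same aryl part but with other groups, so it shows that this part weighs heavily without fixing a direction for the present change. Since compound 2 stands at the limit, a lower number or again a limit is all that can follow. Compound 3 is expected to stay weak, at 8000 nM (between 1000 nM and 30000 nM), which means an expected at least 1.2-fold lower number from compound 2 to compound 3 (0.09 log units; that floor lies within the scatter).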

Compound 3, half-maximal inhibitory concentration: > 10000 nM
Compound 3 gave a limit, no number; the forecaster's own chance of this, stated with the estimate: 60%; middle value at least 1.2-fold (0.09 log units) from the limit.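

Compound 2 and compound 3 are both reported only as a limit of the test, so no step can be read between them: the limit of > 10000 nM in this assay, at which 2 of the 3 values shown sit.

The compounds shown leave open whether 3,4-dichlorophenyl and 4-fluorophenyl differ at all in their effect on these cells, and by how much.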